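Cyclohexyl for methoxyphenyl on the ring amide nitrogen

The compounds below may be only part of what the source reports. "The series", "measured", "known", "first", "only" and "open" are said of these compounds alone.

Four compounds share a fused bicyclic core carrying a ring amide nitrogen and a fluorophenylsulfonamide-bearing aryl group. Compound 1 `O=C1COc2ccc(-c3cnc(Cl)c(NS(=O)(=O)c4ccc(F)cc4)c3)cc2N1C1CCCCC1` and compound 2 `COc1ccc(N2C(=O)COc3ccc(-c4cnc(Cl)c(NS(=O)(=O)c5ccc(F)cc5)c4)cc32)cc1` carry the chloro-substituted heteroaryl core; compound 3 `COc1ccc(N2C(=O)COc3ccc(-c4cccc(NS(=O)(=O)c5ccc(F)cc5)c4)cc32)cc1` and compound 4 `O=C1COc2ccc(-c3cccc(NS(=O)(=O)c4ccc(F)cc4)c3)cc2N1C1CCCCC1` carry a plain aryl core instead. How the two cores differ is not broken down here.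

In a functional assay on HepG2 cells (Homo sapiens) for antiproliferative activity, read by MTT assay, with a stated time of 72 h (on this read-out higher numbers stand for weaker inhibition and lower numbers for stronger inhibition), compound 2 reaches only the limit of the assay, > 40000 nM. Compound 1 likewise gives only a limit in this assay, > 40000 nM. Going by the values given here, compound 3 is the one compound with a read number, 29800 nM in this assay. The change cyclohexyl in place of 4-methoxyphenyl on an amide-type nitrogen in a ring therefore gives a step that the two limits leave unreadable from compound 2 to compound 1; this rests on (the limit of > 40000 nM in this assay, at which 2 of the 3 values shown sit), which leaves both ends of that step unread.

The change from compound 3 to compound 4 is the same change, (cyclohexyl in place of 4-methoxyphenyl on an amide-type nitrogen in a ring), made on a different core. Since the measured instance of this change cannot be read, the expectation for compound 4 can only rest on compound 3 at 29800 nM, with a step assumed to lie within the usual scatter. Compound 4 is therefore expected to give about 35000 nM in this assay, with a range from 15000 nM to 80000 nM. This expectation amounts to an estimated step of a 1.2-fold higher number from compound 3 to compound 4 (0.07 log units; within the scatter). Because compound 3 already sits close to the limit of > 40000 nM in this assay, at which 2 of the 3 values shown sit, there is a real chance that compound 4 is reported only as a limit.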

Compound 4, half-maximal inhibitory concentration: 35900 nM
The estimate for compound 4 lay 1.0-fold (0.01 log units) below the measured number; measured number inside the range.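

On the core of compound 3, cyclohexyl in place of 4-methoxyphenyl on the ring amide nitrogen gives, in this assay, a step that stays within the scatter (a 1.2-fold higher number from compound 3 to compound 4 (0.08 log units; within the scatter)). This readable instance therefore does not separate the aromatic ring from the non-aromatic one on this core, and it rests on one pair of compounds only. It does not show that the change carries over from one core to the other, since the same change on the chloro-substituted core, from compound 2 to compound 1, cannot be read because both of its ends are limits: the limit of > 40000 nM in this assay, at which 2 of the 4 values shown sit.

The compounds shown leave open whether a different kind of group on the ring amide nitrogen, such as a carboxylic acid or a chain ending in an amine, would give a step beyond the scatter from compound 3 in this assay. Also open, from the compounds shown here alone, is whether anything other than the fluorophenyl group on the sulfonamide, for example a plain methyl group, would shift the number on either core, as every compound here carries that same group.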